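Pyridin-2-yl for pyrimidin-2-yl: notes on receptor binding

This account rests on a few compounds, and the source may have more. Where it says the series, first, only, none or still open, it means among the compounds named here.

Measured in an assay on HEK293 cells for displacement of a labelled ligand from D(4) dopamine receptor (Homo sapiens), read by scintillation counting, with a stated time of 90 min; on this read-out higher numbers stand for weaker inhibition and lower numbers for stronger inhibition:
compound 1, `Cc1cccc(NC(=O)CCN2CCN(c3ccccn3)CC2)c1`: 32.2 nM
compound 2, `Cc1cccc(NC(=O)CCN2CCN(c3ncccn3)CC2)c1`: 33 nM
compound 3, `Cc1cccc(NC(=O)CN2CCN(c3ncccn3)CC2)c1`: 5.66 nM

Compound 2 and compound 1 differ in one place, (pyridin-2-yl in place of pyrimidin-2-yl on an amine nitrogen in a ring); in this assay this gives a 1.0-fold lower number from compound 2 to compound 1 (0.01 log units; within the scatter), so the two are not told apart. Compound 3 shares its aryl group with compound 2 but has a different core; how the two cores differ is not broken down here. Compound 3 holds the lowest number of the three, and both compound 1 and compound 2 lie beyond the scatter above it.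

Compound 4, `Cc1cccc(NC(=O)CN2CCN(c3ccccn3)CC2)c1`, is still to be measured in this assay. It differs from compound 3 by pyridin-2-yl in place of pyrimidin-2-yl on an amine nitrogen in a ring. The place is described in the same words as for the change from compound 2 to compound 1, so it is the same change made on the core of compound 3. Because that change gave a 1.0-fold lower number from compound 2 to compound 1 (0.01 log units; within the scatter), the step to compound 4 is expected to be small, a 1.1-fold higher number from compound 3 to compound 4 (0.03 log units; within the scatter). Compound 4 is accordingly estimated at 6 nM, between 2.5 nM and 14 nM.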

Compound 4, inhibition constant: 1.89 nM
For compound 4 the middle estimate is 3.2-fold (0.50 log units) above the measured one, outside the stated range (below it).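

Pyridin-2-yl in place of pyrimidin-2-yl on an amine nitrogen in a ring is not a silent change on every core in this assay, as it gives a 3.0-fold lower number from compound 3 to compound 4 (0.48 log units; beyond the scatter). The size of the step therefore does not carry over unchanged from one core to the other: the same change on two cores in this assay, a 1.0-fold lower number (0.01 log units; within the scatter) from compound 2 to compound 1 and a 3.0-fold lower number (0.48 log units; beyond the scatter) from compound 3 to compound 4, 2.9-fold (0.47 log units) apart, beyond the scatter of two such steps This shows a dependence on the core for this one change across two cores only, with a single pair on each; it does not explain the difference, and it gives no rule for predicting the step on any further core.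

The compounds shown leave open how a phenyl or a pyrazin-2-yl group on the same ring nitrogen would read on either core. Also open, on these data alone, is whether a longer chain than that of compound 1 would keep the change as small as on the core of compound 1 or bring it closer to the step seen on the core of compound 3.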